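A few compounds are considered here, and "the series" means these few. Any claim that something is new, unique, unknown or untested is made for them only; others in the source may bear on it.

In a functional assay on HCT-116 cells (Homo sapiens) for cytotoxicity, read by MTT assay, with a stated time of 72 h (on this read-out higher numbers stand for weaker inhibition and lower numbers for stronger inhibition), compound 2 `NCCNc1c(C(=O)NCc2ccc(F)cc2)nc(Br)c2cccnc12` gives > 20000 nM, a limit of the assay rather than a number. Compound 1 `Nc1ccc(Nc2c(C(=O)NCc3ccc(F)cc3)nc(Br)c3cccnc23)cc1` gives 7000 nM in this assay, so the change of 2-aminoethyl in place of 4-aminophenyl gave an at least 2.8-fold higher number from compound 1 to compound 2 (0.45 log units; beyond the scatter). Compound 3 `O=C(NCCCNc1c(C(=O)NCc2ccc(F)cc2)nc(Br)c2cccnc12)c1ccccc1` gives > 10000 nM, also a limit. Hence a step that the two limits leave unreadable from compound 2 to compound 3 cannot be read. Compound 4 `C[C@H](Nc1c(C(=O)NCc2ccc(F)cc2)nc(Br)c2cccnc12)c1ccccc1` carries 1-phenylethyl in place of 2-aminoethyl on a nitrogen on an aromatic ring. For the measured compounds named here, the only readable step at this nitrogen is the one from compound 1 to compound 2, where a ring on that nitrogen went with the lower number, while the step to compound 3 says nothing. A return toward the region of compound 1 is therefore expected, as an at least 2.5-fold lower number from compound 2 to compound 4 (0.39 log units; beyond the scatter). The estimate for compound 4 is 8000 nM, in a range from 2500 nM to 25000 nM.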

Compound 4, half-maximal inhibitory concentration: > 20000 nM
Compound 4 was reported as a limit; the forecaster's own chance of this, stated with the estimate: 30%; at least 2.5-fold (0.39 log units) between middle value and limit.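

A six-membered aromatic ring on this nitrogen is not enough on its own: 1-phenylethyl in place of 4-aminophenyl gives an at least 2.8-fold higher number from compound 1 to compound 4 (0.45 log units; beyond the scatter). Compound 4 stands at a limit of the assay, not at a number: the limit of > 20000 nM in this assay, at which 2 of the 4 values shown sit. The steps from compound 2 to compound 3 and to compound 4 cannot be read.

For the compounds shown here, compound 1 remains the only compound here with a measured number. Going by these compounds, whether that number depends on the amine of its 4-aminophenyl group stays open, and a plain phenyl or a benzyl group on this nitrogen would help to settle it.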